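This account rests on a few compounds, and the source may have more. Where it says the series, first, only, none or still open, it means among the compounds named here.

Compound 1 `CCc1ccc(NC(=O)N[C@@H](C)c2ccccc2)cc1`: 91%
Compound 2 `CCCc1ccc(NC(=O)N[C@@H](C)c2ccccc2)cc1`: 73%
Compound 3 `CCCCCc1ccc(NC(=O)N[C@@H](C)c2ccccc2)cc1`: 93%

In an ADME assay on the whole organism with Oryza sativa as the target, tested at 10 uM (a lower number here means a stronger effect, a higher number a weaker effect of the compound at the concentration tested), compound 3 gives the highest of the three numbers, but its separation from compound 1 is only a number 2 percentage points higher from compound 1 to compound 3 (within the scatter), whereas against compound 2 the step is a number 20 percentage points higher from compound 2 to compound 3 (beyond the scatter). Compound 4 `CCCCCCCc1ccc(NC(=O)N[C@@H](C)c2ccccc2)cc1` differs from compound 3 by ethyl in place of hydrogen on a saturated chain carbon, five bonds along the chain from an aromatic carbon. Going by the values given here, the steps that bear on this are all chain extensions on the same side: a number 18 percentage points lower from compound 1 to compound 2 (beyond the scatter), a number 20 percentage points higher from compound 2 to compound 3 (beyond the scatter) and a number 2 percentage points higher from compound 1 to compound 3 (within the scatter). They point in no consistent direction, so no step beyond the scatter is expected, and for compound 4 the estimate is 88% (range 70% to 100%), a step of a number 5 percentage points lower from compound 3 to compound 4 (within the scatter).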

Compound 4, a percentage reported as activity, at one concentration (the size of the read-out at that concentration, not a potency): 99%
Beside the measured number, compound 4's estimate is 11 percentage points below it; measured number inside the range.
By their numbers in this assay, from the lowest: compound 2; then compounds 1, 3 and 4 (each within the scatter of the next).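

In this assay, ethyl in place of hydrogen on a saturated chain carbon, five bonds along the chain from an aromatic carbon, gives a number 6 percentage points higher from compound 3 to compound 4 (within the scatter) and so leaves the number where it was, while a number 8 percentage points higher from compound 1 to compound 4 (within the scatter) shows the same for pentyl in place of hydrogen. Only compound 2 stands apart, with a number 26 percentage points higher from compound 2 to compound 4 (beyond the scatter) for the butyl change, so extending the chain further does not bring a lower number. Nothing available explains why compound 2 alone differs.

On these data alone, whether a longer chain, or an amine or a carboxylic acid in place of the chain, would lower the number remains open.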